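Swapping the Halogenated Phenyl on an Inactive Amide

The source may report more compounds than this note shows. Statements on the series, on what has been measured and on what is new or still open speak of the compounds shown alone.

Compound 1 `CC(C)n1ncc2c(C(=O)Nc3cccnc3)cccc21` and compound 2 `CC(C)n1ncc2c(C(=O)NCc3cn(-c4cccc(Br)c4)nn3)cccc21` were both tested in a functional assay on HepG2 cells (Homo sapiens) for inhibition, read by MTT assay, with a stated time of 72 h; a lower number here means a stronger inhibitor, a higher number a weaker inhibitor. In this assay compound 1 gives only a limit, > 40000 nM. Compound 2 likewise gives only a limit in this assay, > 40000 nM. Both values sit on the same line: the limit of > 40000 nM in this assay, at which 2 of the 2 values shown sit. Compound 2 therefore stands at the edge of what this assay can report, with no number of its own.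

Compound 3 `CC(C)n1ncc2c(C(=O)NCc3cn(-c4ccccc4F)nn3)cccc21` has not yet been measured. It differs from compound 2 in one place: 2-fluorophenyl in place of 3-bromophenyl on an aromatic nitrogen. Within the data shown here, no measured step shows what such a change does here, so no movement beyond the usual scatter is expected. The step from compound 2 to compound 3 is expected to be a number no higher from compound 2 to compound 3 (the limit leaves the size open). Compound 3 is estimated at 40000 nM, between 15000 nM and 150000 nM, and the most likely outcome is once more a limit rather than a number.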

Compound 3, half-maximal inhibitory concentration: > 40000 nM
Compound 3 gave a limit, no number; the forecaster's own chance of this, stated with the estimate: 75%; the middle value sits exactly at the limit.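

Among these compounds, compound 2 and compound 3 each give only a limit, not a number, so no step between them can be read: the limit of > 40000 nM in this assay, at which 3 of the 3 values shown sit. Left open is whether any change to the shared core or its side groups would give a number of its own in this assay.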